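Vinyl for fluoro on a shared trimethoxyphenyl-bearing core

The compounds below may be only part of what the source reports. "The series", "measured", "known", "first", "only" and "open" are said of these compounds alone.

Measured compounds:
compound 1, `COc1cc(-c2ccnc3cc(-c4ccc(F)cc4)nn23)cc(OC)c1OC`, 5030 nM
compound 2, `COc1cc(-c2ccnc3cc(-c4ccc(C)c(C)c4)nn23)cc(OC)c1OC`, 261 nM

Compound 1 stands highest of the two numbers in a functional assay on HCT-116 cells (Homo sapiens) for inhibition, read by CCK-8 assay, with a stated time of 48 h (on this read-out lower numbers stand for stronger inhibition and higher numbers for weaker inhibition), with compound 2 as its nearest neighbour at a 19-fold lower number from compound 1 to compound 2 (1.28 log units; beyond the scatter). The unmeasured compound 3, `C=Cc1ccc(-c2cc3nccc(-c4cc(OC)c(OC)c(OC)c4)n3n2)cc1`, differs from compound 1 by vinyl in place of fluoro on an aromatic carbon. For the measured compounds named here, the step that bears on this change is the one from compound 1 to compound 2, where 3,4-dimethylphenyl in place of 4-fluorophenyl on an aromatic carbon gave a 19-fold lower number from compound 1 to compound 2 (1.28 log units; beyond the scatter), a large move. Compound 3 likewise swaps the fluoro for a carbon group, though a single vinyl rather than two methyls, so a smaller but still downward step is expected, a 4.2-fold lower number from compound 1 to compound 3 (0.62 log units; beyond the scatter). Compound 3 is therefore estimated at 1200 nM, with a range from 350 nM to 4000 nM.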

Compound 3, half-maximal inhibitory concentration: 1060 nM
For compound 3 the middle estimate is 1.1-fold (0.05 log units) above the measured one; the range from low to high includes it.
By their numbers in this assay, from the lowest: compound 2; then compound 3; then compound 1.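

In this assay the change of fluoro to vinyl on the aromatic carbon para to a large group gives a 4.7-fold lower number from compound 1 to compound 3 (0.68 log units; beyond the scatter), which shows that a single carbon group at this place, without the second methyl of compound 2, is enough to move the number beyond the scatter. The 4-vinylphenyl group does not reach the level of the 3,4-dimethylphenyl group, however: the listed step is a 4.1-fold higher number from compound 2 to compound 3 (0.61 log units; beyond the scatter), so the large drop seen earlier is only partly matched by this one change. Nothing in the data at hand accounts for this order among the three groups.

As far as these compounds go, it remains open whether the lowering is confined to carbon groups or would also appear with an amine or a carboxylic acid on the same aromatic carbon. Also open, from the compounds shown here alone, is whether a single methyl or a longer chain such as propyl would fall nearer compound 2 or nearer compound 3.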